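Arylsulfonyl fluorine position in a pyrrolidine-arylpiperazine series

The source may report more compounds than this note shows. Statements on the series, on what has been measured and on what is new or still open speak of the compounds shown alone.

Compound 1 `COc1ccccc1N1CCN(CC[C@H]2CCCN2S(=O)(=O)c2ccc(F)cc2)CC1` is the reference point of the pair measured so far. In an assay on CHO cells for displacement of a labelled ligand from 5-hydroxytryptamine receptor 7 (Homo sapiens) (a higher number here means a weaker inhibitor, a lower number a stronger inhibitor), compound 1 gives 4.8 nM, the lowest of the two numbers. Among the measured compounds shown here, compound 2 `CC1CCN(CC[C@H]2CCCN2S(=O)(=O)c2ccc(F)cc2)CC1` is the nearest neighbour, and in this assay compound 2 gives 14 nM, a gap beyond the scatter, though with no single-point step between the two compounds nothing further can be read from it.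

Compound 3 `COc1ccccc1N1CCN(CC[C@H]2CCCN2S(=O)(=O)c2ccccc2F)CC1` keeps the whole of compound 1 apart from one rearrangement: 2-fluorophenyl in place of 4-fluorophenyl on a sulfonyl sulfur. For the measured compounds named here, no measured step of this kind exists, so the direction is uncertain. The step from compound 1 to compound 3 is expected to be small, a 1.5-fold higher number from compound 1 to compound 3 (0.16 log units; within the scatter), probably within the scatter. Compound 3 is therefore estimated at 7 nM in this assay, in a range from 2 nM to 25 nM.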

Compound 3, antagonist equilibrium constant: 1.6 nM
For compound 3 the middle estimate is 4.4-fold (0.64 log units) above the measured one; the whole stated range lies above it.
By their numbers in this assay, from the lowest: compound 3; then compound 1; then compound 2.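

In this assay, among the compounds shown here, the change from 4-fluorophenyl to 2-fluorophenyl on the sulfonyl sulfur gives a 3.0-fold lower number from compound 1 to compound 3 (0.48 log units; beyond the scatter) and is the first single-point step, modest in size but beyond the scatter. The two compounds have the same atoms joined differently, so the read-out at this position responds to where the fluorine sits on the phenyl ring, with the lower number going to the 2-fluorophenyl form on the core of compound 1. Nothing at hand bears on the reason for this step.

Going by these compounds, whether the same change gives a step of like direction and size on the core of compound 2 remains open. Also open, on these data alone, is how unsubstituted phenyl, 2-chlorophenyl or 2-methoxyphenyl on the same sulfonyl sulfur would compare with 2-fluorophenyl.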